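Moving the acid and adding a methyl on the outer ring

A few compounds are considered here, and "the series" means these few. Any claim that something is new, unique, unknown or untested is made for them only; others in the source may bear on it.

Three compounds share a core in which a four-carbon chain joins two aromatic rings through oxygen, one ring carrying a branched ketone and the other a carboxylic acid. Compound 1 `Cc1c(OCCCCOc2cccc(C(=O)O)c2)ccc(C(=O)CC(C)C)c1C` gives 18.3% in an assay on HEK293 cells for positive allosteric modulation of metabotropic glutamate receptor 3 (Rattus norvegicus), read by thallium flux, with a stated time of 2.5 min; on this read-out lower numbers stand for smaller maximal responses and higher numbers for larger maximal responses. Compound 2 `COc1ccc(C(=O)O)cc1OCCCCOc1ccc(C(=O)CC(C)C)c(O)c1C` reaches 100% in this assay, and compound 3 `Cc1c(OCCCCOc2cccc(C(=O)O)c2)ccc(C(=O)CC(C)C)c1O` reaches 69.9%. Compound 3 therefore stands second of the three: below compound 2 and well above compound 1. The step of a number 51.6 percentage points higher from compound 1 to compound 3 (beyond the scatter) changed the ketone-bearing ring, whereas a number 30.1 percentage points lower from compound 2 to compound 3 (beyond the scatter) stripped a substituent from the acid-bearing ring.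

Compound 4 `Cc1cc(C(=O)O)ccc1OCCCCOc1ccc(C(=O)CC(C)C)c(O)c1C` has not yet been measured. It differs from compound 3 on the acid-bearing side: 4-carboxy-2-methylphenyl in place of 3-carboxyphenyl on an oxygen on a saturated carbon. Within the data shown here, the step that bears on this change is the one from compound 2 to compound 3, where removing a group from that same ring lowered the maximal response by a large margin; compound 4 puts a group back onto that ring, with the acid shifted, so a rise is expected rather than a fall, though the acid position differs from compound 2 and the size is uncertain. Compound 4 is expected to give 88% in this assay, within 60% to 100%, an estimated step of a number 18.1 percentage points higher from compound 3 to compound 4 (beyond the scatter).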

Compound 4, largest response reached (reported as percent of maximum), in percent of the reference or control that the assay uses: 42.1%
Compound 4: the middle estimate sits 45.9 percentage points above what was measured, outside the stated range (below it).
By their numbers in this assay, from the lowest: compound 1; then compound 4; then compound 3; then compound 2.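

Swapping 3-carboxyphenyl for 4-carboxy-2-methylphenyl on an oxygen on a saturated carbon gives a number 27.8 percentage points lower from compound 3 to compound 4 (beyond the scatter) in this assay, so the maximal response depends on how the acid-bearing ring is substituted, not just on whether it carries an extra group. The earlier step on this ring, a number 30.1 percentage points lower from compound 2 to compound 3 (beyond the scatter), showed only a loss when a methoxy group was removed; this new step shows that adding a methyl group while the acid changes place does not restore the response and instead lowers it. Because two things change at once here, the acid position and the added methyl, this single step cannot assign the fall to either one, and nothing measured here explains it.

The compounds shown leave open what the shifted acid does with no methyl on the ring, and what the methyl does with the acid left where compound 3 has it. They also leave open whether an ethyl group in place of that methyl, or a tetrazole in place of the carboxylic acid, would raise or lower the response.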